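A few compounds are considered here, and "the series" means these few. Any claim that something is new, unique, unknown or untested is made for them only; others in the source may bear on it.

Of the compounds shown here, two have been measured in a functional assay on NCI-H460 cells (Homo sapiens) for antiproliferative activity, read by MTT assay, with a stated time of 72 h; a higher number here means a weaker inhibitor, a lower number a stronger inhibitor. Compound 1, `CN(C)CCn1cnnc1-c1cc(Oc2ccc(NC(=O)Nc3cccc(C(F)(F)F)c3)cc2F)ccn1`, gives 2150 nM in this assay. Compound 2, `CN(C)CCCn1cnnc1-c1cc(Oc2ccc(NC(=O)Nc3ccc(Cl)c(C(F)(F)F)c3)cc2F)ccn1`, gives 1680 nM in this assay. These two numbers fall within the usual scatter of repeated measurements, so compound 2 stands level with compound 1 rather than apart from it; the two structures also differ in more than one place, so no single change can be read out of their gap.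

Compound 3, `CN(C)CCCn1cnnc1-c1cc(Oc2ccc(NC(=O)Nc3cccc(C(F)(F)F)c3)cc2F)ccn1`, has not yet been measured. It differs from compound 2 in one place: hydrogen in place of chloro on an aromatic carbon. Among the compounds with values here, no measured pair in this set shows what this particular change does, so the expectation rests on the two numbers alone. A swap of one chlorine for a hydrogen is expected to move the number only a little, and the step of a 1.5-fold higher number from compound 2 to compound 3 (0.17 log units; within the scatter) is expected to be modest, if anything toward a weaker inhibitor. Compound 3 is therefore estimated at 2500 nM in this assay, with a range from 1000 nM to 6000 nM.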

Compound 3, half-maximal inhibitory concentration: 1790 nM
Estimate against measurement, compound 3: 1.4-fold (0.15 log units) above, and the stated range covers the measured number.
By their numbers in this assay, from the lowest: compounds 2, 3 and 1 (each within the scatter of the next).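

In this assay the chloro of the 4-chloro-3-(trifluoromethyl)phenyl group can give way to hydrogen, leaving 3-(trifluoromethyl)phenyl, with a 1.1-fold higher number from compound 2 to compound 3 (0.03 log units; within the scatter) and compound 2 and compound 3 standing level. So on this aromatic carbon, ortho to the trifluoromethyl group and para to a large group, this single swap shows no measurable effect in the assay, something the earlier pair could not show while their structures differed in more than one place. Compound 3 also provides a second single-change comparison, (dimethylamino)methyl in place of dimethylamino on the saturated chain, with a 1.2-fold lower number from compound 1 to compound 3 (0.08 log units; within the scatter) and so again no separation between the pair, and nothing measured here goes beyond these numbers to explain either result.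

Going by these compounds, whether this ring carbon tolerates other groups remains open, since a methoxy group, a nitrile or a fluorine there could behave differently from chloro and hydrogen. The chain also leaves questions open: a longer chain, or a morpholine or piperidine in place of the dimethylamino group, could still separate from these compounds.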